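Thiophene for Methoxyphenyl on the Sulfonyl: Maximal Response

The source may hold more compounds than are shown below. What is called first, only, known or untested is meant among the compounds shown, and "the series" means these compounds.

The three compounds measured so far, all in a functional assay on HeLa cells for antagonist activity at 5-hydroxytryptamine receptor 6 (Homo sapiens); on this read-out lower numbers stand for smaller maximal responses and higher numbers for larger maximal responses:
compound 1, `CN1CCN(c2ccc3[nH]nc(S(=O)(=O)c4c(Cl)cccc4Cl)c3c2)CC1`, gives 100%;
compound 2, `CN1CCN(c2ccc3[nH]nc(S(=O)(=O)c4ccc(F)cc4)c3c2)CC1`, gives 98%;
compound 3, `COc1ccc(S(=O)(=O)c2n[nH]c3ccc(N4CCN(C)CC4)cc23)cc1`, gives 100%.

Compound 3 stands level with compound 1 at the digits printed, the two together the highest of the three numbers. Its nearest neighbour is compound 1, with no change at the digits printed from compound 1 to compound 3 (within the scatter). Its furthest neighbour is compound 2, and the step runs a number 2 percentage points higher from compound 2 to compound 3 (within the scatter). All three numbers therefore sit within the scatter of one another.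

Compound 4, `CN1CCN(c2ccc3[nH]nc(S(=O)(=O)c4cccs4)c3c2)CC1`, has not yet been measured. It differs from compound 3 in one place: thiophen-2-yl in place of 4-methoxyphenyl on a sulfonyl sulfur

Among the compounds with values here, two measured steps bear on this change, since both also exchange the aryl group on the sulfonyl sulfur while the rest of the shared core is kept: a number 2 percentage points lower from compound 1 to compound 2 (within the scatter), and no change at the digits printed from compound 1 to compound 3 (within the scatter). Neither exchange moved the maximal response beyond the scatter, so for compound 4 no step beyond the scatter is expected in this assay either; the expected step is a number 1 percentage points lower from compound 3 to compound 4 (within the scatter). Compound 4 is thus estimated at 99%, with a range from 88% to 108%.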

Compound 4, largest response reached (reported as Imax), in percent of the reference or control that the assay uses: 96%
Compound 4: the middle estimate sits 3 percentage points above what was measured, and the stated range covers the measured number.
By their numbers in this assay, from the lowest: compounds 4, 2, 1 and 3 (each within the scatter of the next).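

In this assay, within the data shown here, thiophen-2-yl brings a five-membered aromatic ring with a sulfur hetero atom to the sulfonyl sulfur, where the earlier compounds carried only six-membered aromatic rings of carbon, and the exchange gives a number 4 percentage points lower from compound 3 to compound 4 (within the scatter) even though the group falls from 8 heavy atoms to 5. The comparisons with the other two aryl groups read the same way, with a number 2 percentage points lower from compound 2 to compound 4 (within the scatter) for the 4-fluorophenyl group and a number 4 percentage points lower from compound 1 to compound 4 (within the scatter) for the 2,6-dichlorophenyl group, so no exchange among these four groups on the sulfonyl sulfur moves the maximal response beyond the scatter. Nothing at hand explains why the read-out holds across these four groups.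

All four groups are aromatic rings attached directly to the sulfonyl sulfur, so the compounds shown leave open what a methyl, a cyclohexyl or a benzyl group would do in this position. They also leave open whether an aryl group carrying an amine or a carboxylic acid would fit the same picture, and whether it would still hold with a different substituent elsewhere on the shared core.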